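The source may report more compounds than this note shows. Statements on the series, on what has been measured and on what is new or still open speak of the compounds shown alone.

Working notes on the series. In a functional assay on cells (T-cell, Mus musculus, strain BALB/c) for inhibition, read by MTT assay, with stated times of 24 h and 72 h (a lower number here means a stronger inhibitor, a higher number a weaker inhibitor), compound 1 `COc1cc(-c2nnc(SCc3c(F)cccc3F)o2)ccc1O` gives 10100 nM; compound 2 `COc1cc(-c2nnc(SCc3ccccc3)o2)ccc1O` gives 1250 nM; compound 3 `COc1cccc(CSc2nnc(-c3ccc(O)c(OC)c3)o2)c1` gives 7410 nM. Compound 2 has the lowest number of the three: an 8.1-fold lower number from compound 1 to compound 2 (0.91 log units; beyond the scatter), and a 5.9-fold higher number from compound 2 to compound 3 (0.77 log units; beyond the scatter).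

Compound 4 `COc1cc(-c2nnc(SCc3ccccc3)o2)ccc1OCc1ccccc1` follows from compound 2 by benzyl in place of hydrogen on an oxygen on an aromatic ring. Going by the values given here, none of the measured steps touches this oxygen: an 8.1-fold lower number from compound 1 to compound 2 (0.91 log units; beyond the scatter), a 1.4-fold lower number from compound 1 to compound 3 (0.13 log units; within the scatter) and a 5.9-fold higher number from compound 2 to compound 3 (0.77 log units; beyond the scatter) all alter the arene on the saturated chain carbon bound to a sulfur. With no direct guide, a step at most modestly beyond the scatter is expected, a 1.8-fold higher number from compound 2 to compound 4 (0.25 log units; within the scatter), with wide uncertainty. Compound 4 is therefore estimated at 2200 nM, in a range from 600 nM to 8000 nM.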

Compound 4, half-maximal inhibitory concentration: 13300 nM
Beside the measured number, compound 4's estimate is 6.0-fold (0.78 log units) below it; measured number outside the range, above it.
By their numbers in this assay, from the lowest: compound 2; then compounds 3, 1 and 4 (each within the scatter of the next).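

Going by these compounds alone, the oxygen on the aromatic ring is the first place where a change away from the arene on the saturated chain carbon can be read, and in this assay hydroxy to benzyloxy gives an 11-fold higher number from compound 2 to compound 4 (1.03 log units; beyond the scatter), a large step. This oxygen is therefore not indifferent to substitution, at least for benzyl on the core of compound 2. Nothing available bears on the reason for this step.

On these data alone, whether methyl or a chain carrying an amine on this oxygen would give a step of like size stays open. Also open, as far as these compounds go, is whether the step holds with 3-methoxyphenyl or 2,6-difluorophenyl on the saturated chain carbon bound to a sulfur.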